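The source may hold more compounds than are shown below. What is called first, only, known or untested is meant among the compounds shown, and "the series" means these compounds.

Measured so far in an assay on CHO cells for displacement of a labelled ligand from 5-hydroxytryptamine receptor 1D (Homo sapiens); on this read-out higher numbers stand for weaker inhibition and lower numbers for stronger inhibition:

Compound 1, `O[C@@H]1Cc2ccccc2[C@H]1NC1CCN(CCCc2c[nH]c3ccc(-n4cnnc4)cc23)CC1`, gives 6.6 nM.
Compound 2, `c1ccc2c(c1)CCC2NC1CCN(CCCc2c[nH]c3ccc(-n4cnnc4)cc23)CC1`, gives 8.9 nM.
Compound 3, `c1cc(CNC2CCN(CCCc3c[nH]c4ccc(-n5cnnc5)cc34)CC2)co1`, gives 4.5 nM.

Compound 3 carries the lowest of the three numbers, but its separation from the others is small: a 1.5-fold lower number from compound 1 to compound 3 (0.17 log units; within the scatter) and a 2.0-fold lower number from compound 2 to compound 3 (0.30 log units; within the scatter), both within the scatter, as is a 1.3-fold higher number from compound 1 to compound 2 (0.13 log units; within the scatter). Across these three compounds the group on the amine nitrogen has been varied without any shift in this assay that exceeds the scatter.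

Compound 4, `CN(Cc1ccccc1)CC1CCN(CCCc2c[nH]c3ccc(-n4cnnc4)cc23)CC1`, is not yet measured. Its difference from compound 3 is (benzyl(methyl)amino)methyl in place of ((furan-3-yl)methyl)amino on a saturated ring carbon. This change goes beyond the earlier ones in two ways: the amine is no longer attached directly to the saturated ring carbon but through a methylene, and the nitrogen carries a methyl so that the hydrogen-bond donor is lost. None of the three measured steps involves a change of this kind; they only exchange the group on the nitrogen, and all stayed within the scatter. Going by these compounds, that history argues for a modest outcome, but the added methylene and the removed donor are untested here, so a weakening beyond the scatter is plausible. For compound 4 the expected step is a 2.7-fold higher number from compound 3 to compound 4 (0.43 log units; beyond the scatter), toward a higher number. The estimate for compound 4 in this assay is 12 nM, with a range from 4 nM to 40 nM.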

Compound 4, half-maximal inhibitory concentration: 0.9 nM
Beside the measured number, compound 4's estimate is 13-fold (1.12 log units) above it; the measured number lies below the stated range.
By their numbers in this assay, from the lowest: compound 4; then compounds 3, 1 and 2 (each within the scatter of the next).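

In this assay, among the compounds shown here, the saturated ring carbon three ring bonds from the ring nitrogen yields the first steps beyond the scatter, with (benzyl(methyl)amino)methyl as the entering group (a 5.0-fold lower number from compound 3 to compound 4 (0.70 log units; beyond the scatter)), (a 9.9-fold lower number from compound 2 to compound 4 (1.00 log units; beyond the scatter)) and (a 7.3-fold lower number from compound 1 to compound 4 (0.87 log units; beyond the scatter)). Exchanging the group on the amine nitrogen had produced no such separation, whereas this larger change does, and all three steps run toward a lower number even though the entering group has no hydrogen-bond donor, so a donor at this place is not required for a low number in compound 4. No measurement shown here bears on the cause of these steps.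

Going by these compounds, the entering group differs from each leaving group in its methylene link, its methyl on the nitrogen and its benzyl group at once, so the share of each stays open; the (benzylamino)methyl group and a directly attached benzyl(methyl)amino group would separate them. On these data alone, how an amide at this place, or a longer chain in place of the methylene, would read in this assay also stays open.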